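The source may hold more compounds than are shown below. What is called first, only, known or untested is meant among the compounds shown, and "the series" means these compounds.

Measured so far:
- compound 1, `COc1cccc(C(O)CCn2nc3c(Br)c(Br)c(Br)c(Br)c3n2)c1`, 106%
- compound 2, `OC(CCn1nc2c(Br)c(Br)c(Br)c(Br)c2n1)c1cccc(Cl)c1`, 118%
- compound 3, `C[C@H](O)CCn1nc2c(Br)c(Br)c(Br)c(Br)c2n1`, 112%

In a functional assay on CCRF-CEM cells (Homo sapiens) for antiproliferative activity, read by MTT assay, with a stated time of 24 h, tested at 25 uM (on this read-out higher numbers stand for a weaker effect at the one concentration tested and lower numbers for a stronger effect), compound 2 gives the highest of the three numbers. Its nearest neighbour is compound 3, whose value lies within the scatter of it, so no order between those two can be claimed. The gap to compound 1 is beyond the scatter: a number 12 percentage points higher from compound 1 to compound 2 (beyond the scatter). Among the measured compounds shown here, all three numbers sit at or above the level of untreated cells, so none of the measured compounds shows an antiproliferative effect at this concentration.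

Compound 4, `OC(CCn1nc2c(Br)c(Br)c(Br)c(Br)c2n1)c1ccc(Br)cc1`, has not yet been measured. It differs from compound 2 in one place: 4-bromophenyl in place of 3-chlorophenyl on a saturated chain carbon bound to an oxygen on a saturated carbon and a saturated chain carbon. For the measured compounds named here, no measured step swaps one halogen for another on this ring or moves a group around it. Going by the values given here, the only step at this position, a number 12 percentage points higher from compound 1 to compound 2 (beyond the scatter), is modest and replaces a methoxy group rather than a halogen, so it bears on the change only loosely. With every measured compound inactive and the structural change small, no step beyond the scatter is expected in this assay. Compound 4 is therefore estimated at 112%, between 98% and 126%, which means an expected step of a number 6 percentage points lower from compound 2 to compound 4 (within the scatter).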

Compound 4, a percentage reported as activity, at one concentration (the size of the read-out at that concentration, not a potency): 109%
Estimate against measurement, compound 4: 3 percentage points above, and the stated range covers the measured number.
By their numbers in this assay, from the lowest: compounds 1, 4, 3 and 2 (each within the scatter of the next, the first and the last beyond it).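

In this assay, putting 4-bromophenyl in place of 3-chlorophenyl gives a number 9 percentage points lower from compound 2 to compound 4 (within the scatter), and putting it in place of 3-methoxyphenyl gives a number 3 percentage points higher from compound 1 to compound 4 (within the scatter). Among the compounds shown here, compound 4 therefore lies within the scatter of both compounds that formed the one earlier step beyond the scatter, so three aryl groups at this position do not yet make a clear trend. Like the two earlier aryl compounds, it shows no antiproliferative effect at the one concentration tested, and no measurement here explains the small differences.

Going by these compounds, because the halogen and its ring position change together in compound 4, their separate contributions remain unknown. On these data alone, it also remains open whether an amine or a carboxylic acid on this ring, or a longer chain at this position, would bring the number down.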